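This account rests on a few compounds, and the source may have more. Where it says the series, first, only, none or still open, it means among the compounds named here.

Of the compounds shown here, three built on one shared core have been tested in a functional assay on U-937 cells (Homo sapiens) for cytotoxicity, read by MTT assay, with a stated time of 48 h; on this read-out higher numbers stand for weaker inhibition and lower numbers for stronger inhibition. Compound 1 `Fc1cccc(-c2nc(Nc3ccccc3)c3cc(F)ccc3n2)c1` gives 45500 nM. Compound 3 `Fc1cccc(Nc2nc(-c3cccc(F)c3)nc3ccc(F)cc23)c1` gives 42300 nM, numerically the smaller of the two numbers reported, although the step of a 1.1-fold lower number from compound 1 to compound 3 (0.03 log units; within the scatter) stays within the scatter, so the two cannot be told apart. For compound 2 `Fc1ccc(Nc2nc(-c3cccc(F)c3)nc3ccc(F)cc23)cc1` the assay reports only a limit, > 50000 nM, which is the limit of > 50000 nM in this assay, at which 1 of the 3 values shown sits, rather than a measured number.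

Compound 4 `Fc1cccc(-c2nc(Nc3ccccc3F)c3cc(F)ccc3n2)c1` has not been measured yet. It differs from compound 3 by 2-fluorophenyl in place of 3-fluorophenyl on a nitrogen on an aromatic ring. The steps already measured bear on this: shifting the fluoro between the two phenyl-bearing positions gave an at least 1.1-fold lower number from compound 2 to compound 3 (0.07 log units; that floor lies within the scatter), while adding a fluoro to the plain phenyl gave an at least 1.0-fold higher number from compound 1 to compound 2 (0.04 log units; that floor lies within the scatter) and a 1.1-fold lower number from compound 1 to compound 3 (0.03 log units; within the scatter). None of these moved beyond the scatter, so for compound 4 no step beyond the scatter is expected in this assay, in either direction.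

Compound 4 is therefore estimated at 45000 nM, with a range from 20000 nM to 100000 nM. This estimate corresponds to an expected step of a 1.1-fold higher number from compound 3 to compound 4 (0.03 log units; within the scatter).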

Compound 4, half-maximal inhibitory concentration: > 50000 nM
Compound 4: a limit, no number; the forecaster's own chance of this, stated with the estimate: 40%; middle value at least 1.1-fold (0.04 log units) away from the limit.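

Compound 4 completes the series of 2-fluorophenyl, 3-fluorophenyl and 4-fluorophenyl on the nitrogen, and in this assay it too gives a limit rather than a number: the limit of > 50000 nM in this assay, at which 2 of the 4 values shown sit.

The two readable steps, an at least 1.1-fold higher number from compound 3 to compound 4 (0.07 log units; that floor lies within the scatter) and an at least 1.0-fold higher number from compound 1 to compound 4 (0.04 log units; that floor lies within the scatter), are only floors, so this change shows no measurable shift, though a larger one is not ruled out. Compound 2 and compound 4 both stand at a limit, and the step between them cannot be read.

Among the compounds shown, fluoro is the only group placed on this phenyl ring, so it stays open whether an amine or a carboxylic acid there would give a clearly lower number. As far as these compounds go, how far the true value of compound 4 lies past its limit also stays open.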